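Ethoxy to isopropoxy on the alkoxy series

A few compounds are considered here, and "the series" means these few. Any claim that something is new, unique, unknown or untested is made for them only; others in the source may bear on it.

Measured so far in a functional assay on the whole organism (strain Sprague-Dawley) for inhibition, with Rattus norvegicus as the target, with a stated time of 10 min; a lower number here means that less compound is needed, a higher number that more compound is needed for the effect
compound 1 `Nc1ccccc1-c1ncc(C(=O)O)c(=O)[nH]1` gives 50 mg/kg
compound 2 `CCOc1ccccc1-c1ncc(C(=O)O)c(=O)[nH]1` gives 0.5 mg/kg

Compound 2 holds the lower of the two numbers, and compound 1 lies well beyond the scatter above it. The next change leads to compound 3 `CC(C)Oc1ccccc1-c1ncc(C(=O)O)c(=O)[nH]1` and reads (methyl in place of hydrogen on a saturated chain carbon bound to an oxygen on an aromatic ring and a saturated chain carbon), so ethoxy becomes isopropoxy. Going by the values given here, the only measured step is a 100-fold lower number from compound 1 to compound 2 (2.00 log units; beyond the scatter) and it is large, but it replaces amino with ethoxy and shows nothing direct about a change within the ethoxy group. Only a small shift in this assay is therefore expected, with no firm direction and perhaps a slightly lower number. For compound 3 the estimate is 0.4 mg/kg, with an expected range of 0.1 mg/kg to 1.5 mg/kg as the working bounds. The expected change is a 1.3-fold lower number from compound 2 to compound 3 (0.10 log units; within the scatter) and stays within the scatter.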

Compound 3, dose for 50% inhibition: 0.8 mg/kg
Compound 3: the middle estimate sits 2.0-fold (0.30 log units) below what was measured; measured number inside the range.
By their numbers in this assay, from the lowest: compounds 2 and 3 (each within the scatter of the next); then compound 1.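

In this assay, methyl in place of hydrogen on the saturated chain carbon bound to the oxygen gives a 1.6-fold higher number from compound 2 to compound 3 (0.20 log units; within the scatter) and so leaves ethoxy and isopropoxy indistinguishable in this assay. The large step away from amino is therefore not unique to ethoxy: isopropoxy in its place gives a 63-fold lower number from compound 1 to compound 3 (1.80 log units; beyond the scatter) and stands beyond the scatter in the same direction. No available evidence bears on why this added methyl leaves the number within the scatter.

The compounds shown leave open whether the shorter methoxy or a longer chain such as butoxy stays at this level. They also leave open whether a further methyl on the same carbon, giving tert-butoxy, remains within the scatter of compound 2 and compound 3.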